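Removing a methyl from a pyrazine cinnamide: effect on solubility

The compounds below may be only part of what the source reports. "The series", "measured", "known", "first", "only" and "open" are said of these compounds alone.

Measured compounds:
- Compound 1, `O=C1C=CCCN1C(=O)/C=C/c1ccncc1`: 46.2 ug/mL
- Compound 2, `O=C1C=CCCN1C(=O)/C=C/c1cnc2ccccc2c1`: 1.95 ug/mL
- Compound 3, `Cc1nccnc1/C=C/C(=O)N1CCC=CC1=O`: 48.2 ug/mL

All three compounds were tested in a physicochemical assay for solubility, read by HPLC; on this read-out higher numbers stand for higher solubility and lower numbers for lower solubility. Compound 3 gives 48.2 ug/mL, which is the highest of the three numbers. Compound 1 is its nearest neighbour on these numbers, and the two values lie within the scatter of the measurement, so no order between them can be claimed. Compound 2 is the furthest away, with a number clearly lower than compound 3, beyond the scatter.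

The next compound, compound 4, has the structure `O=C1C=CCCN1C(=O)/C=C/c1cnccn1`. It differs from compound 3 in one place: hydrogen in place of methyl on an aromatic carbon. A methyl leaves and a hydrogen enters on an aromatic carbon of the six-membered aromatic ring with two nitrogens, next to the ring nitrogen.

Among the compounds with values here, no pair of measured compounds differing in only one place is available, so the step cannot be read from any measured pair. Taking away a single carbon is a small change, and the expected step from compound 3 to compound 4 in this assay, a 1.2-fold higher number from compound 3 to compound 4 (0.10 log units; within the scatter), is small, if anything toward a slightly higher number, and likely within the scatter. The estimate for compound 4 in this assay is 60 ug/mL, with a range from 30 ug/mL to 120 ug/mL.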

Compound 4, solubility: 59.8 ug/mL
The estimate for compound 4 lay 1.0-fold (0.00 log units) above the measured number; the range from low to high includes it.
By their numbers in this assay, from the lowest: compound 2; then compounds 1, 3 and 4 (each within the scatter of the next).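

Within the data shown here, this is the first pair here that differs in only one place, so the methyl on an aromatic carbon, next to the ring nitrogen, can now be judged directly in this assay. Hydrogen in place of that methyl gives a 1.2-fold higher number from compound 3 to compound 4 (0.09 log units; within the scatter), so no change can be claimed: with or without the methyl at this place, the read-out shows no difference that repeated measurements could separate. Nothing available explains this outcome, so it stands as an observation without an established cause.

As far as these compounds go, it remains open whether this place would accept something larger or of a different kind, since an amine, a carboxylic acid or a longer alkyl chain on the same aromatic carbon might not behave like a methyl or a hydrogen. It also remains open whether hydrogen in place of methyl would make as little difference on another core, as this single pair is the only example of the change among the compounds shown.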